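This account rests on a few compounds, and the source may have more. Where it says the series, first, only, none or still open, it means among the compounds named here.

Compound 1 `CCn1c(C(=O)Nc2cccc(C(F)(F)F)c2)ccc1C(CC)(CC)c1ccc(OCC(=O)C(C)(C)C)c(C)c1`: in an assay on HL-60 cells for agonist activity at vitamin D3 receptor (Homo sapiens), read by microscopy, with a stated time of 96 h (on this read-out lower numbers stand for an effect already at smaller amounts and higher numbers for an effect only at larger amounts of compound), compound 1 gives > 50000 nM, which is a limit of the assay.
Compound 2 `CCOc1ccc(NC(=O)c2ccc(C(CC)(CC)c3ccc(OCC(=O)C(C)(C)C)c(C)c3)n2CC)cc1`: in this assay compound 2 gives > 50000 nM, also a limit.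
Compound 3 `CCn1c(C(=O)Nc2cccc(C(F)(F)F)c2)ccc1C(CC)(CC)c1ccc(OCC(O)C(C)(C)C)c(C)c1`: in this assay compound 3 gives > 50000 nM, again a limit.

The change from compound 1 to compound 2 is 4-ethoxyphenyl in place of 3-(trifluoromethyl)phenyl on an amide-type nitrogen. Its step, a step that the two limits leave unreadable from compound 1 to compound 2, cannot be sized. The cores of compound 1 and compound 3 differ by 1-hydroxy-2,2-dimethylpropyl in place of (tert-butyl)carbonyl on a saturated chain carbon bound to an oxygen on an aromatic ring, and that step, a step that the two limits leave unreadable from compound 1 to compound 3, is equally unreadable. Compound 4 `CCOc1ccc(NC(=O)c2ccc(C(CC)(CC)c3ccc(OCC(O)C(C)(C)C)c(C)c3)n2CC)cc1` has not yet been measured in this assay. It carries the same change as 4-ethoxyphenyl in place of 3-(trifluoromethyl)phenyl on an amide-type nitrogen, at the same place. Because (the limit of > 50000 nM in this assay, at which 3 of the 3 values shown sit), compound 4 is expected to remain at that limit, with an estimated value of 80000 nM and a range from 20000 nM to 300000 nM. The expected step is a step that the limit leaves unreadable from compound 3 to compound 4.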

Compound 4, half-maximal effective concentration: 630 nM
The estimate for compound 4 lay 130-fold (2.10 log units) above the measured number; the measured number lies below the stated range.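

In this assay, the step on the core carrying the hydroxy group is large: an at least 79-fold lower number from compound 3 to compound 4 (1.89 log units; beyond the scatter), with 4-ethoxyphenyl in place of 3-(trifluoromethyl)phenyl on the amide-type nitrogen. The second change, 1-hydroxy-2,2-dimethylpropyl in place of (tert-butyl)carbonyl, gives an at least 79-fold lower number from compound 2 to compound 4 (1.89 log units; beyond the scatter), so among these compounds a measurable number appears only where both changes are present. The steps from compound 1 cannot be read, so it is not shown whether the aryl change has any effect on the carbonyl core, and both large steps give only a minimum size: the limit of > 50000 nM in this assay, at which 3 of the 4 values shown sit.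

As far as these compounds go, it remains open how far the effect belongs to the ethoxy group itself. An amine, a carboxylic acid or a longer alkoxy chain at that place on the hydroxy core could test this.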